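The source may report more compounds than this note shows. Statements on the series, on what has been measured and on what is new or still open speak of the compounds shown alone.

Series notes. Going by the values given here, compound 1 `O=C(Nc1cccc(-n2cc(-c3ccncc3)c(-c3ccc(Cl)c(O)c3)n2)c1)Nc1ccc(Cl)c(Cl)c1` in a functional assay on UACC-62 cells (Homo sapiens) for inhibition, read by sulforhodamine B assay, with a stated time of 48 h (a higher number here means a weaker inhibitor of growth, a lower number a stronger inhibitor of growth), gives 5210 nM, the highest of the two numbers measured so far; its nearest neighbour is compound 3 `O=C(Nc1cccc(-n2cc(-c3ccncc3)c(-c3ccc(Cl)c(O)c3)n2)c1)Nc1ccc(Cl)c(C(F)(F)F)c1`, which in this assay gives 1450 nM. Among the compounds with values here, that pair forms the only measured step between compounds differing in a single place: a 3.6-fold lower number from compound 1 to compound 3 (0.56 log units; beyond the scatter). Compound 2 `COc1cc(-c2nn(-c3cccc(NC(=O)c4cccc(C(F)(F)F)c4)c3)cc2-c2ccncc2)ccc1Cl` sits at the limit of > 50000 nM in this assay, at which 1 of the 3 values shown sits; its entry in this assay, > 50000 nM, is a limit rather than a measured number.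

Compound 4 `COc1cc(-c2nn(-c3cccc(NC(=O)Nc4ccc(Cl)c(Cl)c4)c3)cc2-c2ccncc2)ccc1Cl` differs from compound 1 in one place: methyl in place of hydrogen on an oxygen on an aromatic ring. Within the data shown here, no measured step covers this change; the step from compound 1 to compound 3 exchanges chloro for trifluoromethyl elsewhere in the molecule and says nothing about the hydroxy. Among the measured compounds shown here, compound 2 is the only measured compound carrying the 4-chloro-3-methoxyphenyl group, but it also carries an amide in place of the urea, so its limit cannot be apportioned between the two changes. The expectation for compound 4 is therefore a higher number than compound 1, weaker growth inhibition, with a real chance that this assay returns only a limit. For compound 4 the estimate is 15000 nM, with a range from 4000 nM to 50000 nM, which corresponds to an expected step of a 2.9-fold higher number from compound 1 to compound 4 (0.46 log units; beyond the scatter).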

Compound 4, concentration for total growth inhibition: 1860 nM
The estimate for compound 4 lay 8.1-fold (0.91 log units) above the measured number; measured number below the stated range.
By their numbers in this assay, from the lowest: compounds 3 and 4 (each within the scatter of the next); then compound 1. At a limit, above all of these: compound 2.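

Within the urea series, the hydroxy on the 4-chloro-3-hydroxyphenyl group is not needed for growth inhibition in this assay: exchanging it for methoxy gives a 2.8-fold lower number from compound 1 to compound 4 (0.45 log units; beyond the scatter). The 4-chloro-3-methoxyphenyl group therefore cannot by itself account for the poor result of compound 2, since with that group held constant, replacing 3-(trifluoromethyl)phenyl on the carbonyl carbon with (3,4-dichlorophenyl)amino gives an at least 26-fold lower number from compound 2 to compound 4 (1.42 log units; beyond the scatter). That step starts from a limit rather than a measured number: the limit of > 50000 nM in this assay, at which 1 of the 4 values shown sits.

This single step changes both the link to the carbonyl and the substituents on the outer ring, so the compounds shown do not separate the amide-to-urea change from the change of trifluoromethyl to the two chloro groups. On these data alone, it also remains open whether methoxy gives the same result on the trifluoromethyl urea of compound 3, and whether the oxygen position tolerates a longer chain such as ethoxy or a replacement of the oxygen by an amine.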